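A few compounds are considered here, and "the series" means these few. Any claim that something is new, unique, unknown or untested is made for them only; others in the source may bear on it.

Compounds measured so far:
- Compound 1 `CCOC(=O)C1=Cc2ccccc2OC1(OCc1cn(-c2ccc(F)cc2)nn1)C(F)(F)F` gives 8900 nM
- Compound 2 `O=C(O)C1=Cc2ccccc2OC1(OCc1cc(-c2ccc([N+](=O)[O-])cc2)no1)C(F)(F)F` gives 100000 nM
- Compound 3 `COc1ccc(-c2cc(COC3(C(F)(F)F)Oc4ccccc4C=C3C(=O)O)on2)cc1` gives 42000 nM

All three were tested in a functional assay on DU-145 cells (Homo sapiens) for inhibition, read by MTT assay, with a stated time of 24 h; on this read-out higher numbers stand for weaker inhibition and lower numbers for stronger inhibition. Among these numbers compound 1 stands lowest, and its distance to the others lies beyond the usual scatter, so it is the strongest inhibitor of the three. Within the data shown here, compound 2 and compound 3 share a core that differs from that of compound 1, and the only single-point step between measured compounds is between them: a 2.4-fold lower number from compound 2 to compound 3 (0.38 log units; beyond the scatter), where a methoxy replaced a nitro on an aromatic carbon.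

The new compound 4 `CCOC(=O)C1=Cc2ccccc2OC1(OCc1cn(CC(=O)Nc2cccc(Cl)c2)nn1)C(F)(F)F` starts from compound 1. The change is ((3-chlorophenyl)carbamoyl)methyl in place of 4-fluorophenyl on an aromatic nitrogen. Among the measured compounds shown here, no measured step touches this position: the one known step concerns a substituent on an aromatic carbon of a phenyl ring attached to a different five-membered ring, and it tells nothing about what a larger, more flexible group on the ring nitrogen does. For the measured compounds named here, with no precedent, the expectation for compound 4 is a number close to that of compound 1, with no step beyond the scatter, a 1.1-fold higher number from compound 1 to compound 4 (0.05 log units; within the scatter). Compound 4 is therefore estimated at 10000 nM, within a range from 3000 nM to 35000 nM, the width reflecting the missing precedent.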

Compound 4, half-maximal inhibitory concentration: 10100 nM
Estimate against measurement, compound 4: 1.0-fold (0.00 log units) below; the range from low to high includes it.
By their numbers in this assay, from the lowest: compounds 1 and 4 (each within the scatter of the next); then compound 3; then compound 2.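

Replacing 4-fluorophenyl with ((3-chlorophenyl)carbamoyl)methyl on the aromatic nitrogen of the five-membered ring gives, in this assay, a 1.1-fold higher number from compound 1 to compound 4 (0.05 log units; within the scatter), so the two compounds cannot be told apart on this read-out. Among these compounds, this is the first reading at this position, and it shows that the number can stay within the scatter when the group on this nitrogen is exchanged for a larger one that holds an amide, with a hydrogen-bond donor and a hydrogen-bond acceptor that 4-fluorophenyl lacks. No supporting measurement is available to explain why the number holds across this change.

On these data alone, both groups compared here carry a six-membered aromatic ring of carbon only, so it remains open what a group without such a ring, such as a simple amine or a plain alkyl chain, would do on the same nitrogen. As far as these compounds go, it also remains open how much the chlorine counts, as a version with hydrogen or a nitrile in its place would be needed to test it.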